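Amide replacement on the shared core: proline to alanine

A few compounds are considered here, and "the series" means these few. Any claim that something is new, unique, unknown or untested is made for them only; others in the source may bear on it.

Three compounds of the series have a number in a functional assay on the whole organism (Tail, strain ICR) with Mus musculus as the target, in the tail flick test, with a stated time of 120 min, at a dose of 25 umol/kg by the oral route; on this read-out higher numbers stand for a stronger effect at the one dose given and lower numbers for a weaker effect. Compound 1 `O=C(O)[C@@H]1CCCN1C(=O)CN(c1nc(Cl)nc2[nH]cnc12)C1CC1` gives 23.6% in this assay. Compound 2 `CSCC[C@H](NC(=O)CN(c1nc(Cl)nc2[nH]cnc12)C1CC1)C(=O)OCc1ccccc1` gives 31.6%, and compound 3 `CSCC[C@H](NC(=O)CN(c1ncnc2c1ncn2C1CCCCO1)C1CC1)C(=O)OCc1ccccc1` gives 28.7%. The number of compound 1 is the smallest of the three, but its gaps to compound 3 and to compound 2 both lie within the usual scatter, so the three read as one level rather than a ranking.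

Compound 4 `C[C@H](NC(=O)CN(c1nc(Cl)nc2[nH]cnc12)C1CC1)C(=O)O` has not yet been measured. Against compound 1 the change is (1-carboxyethyl)amino in place of 2-carboxypyrrolidin-1-yl on a carbonyl carbon. The carbonyl carbon carrying the change keeps its saturated chain carbon neighbour, and the rest of the shared core is untouched. Within the data shown here, no pair of measured compounds differs in one place, so there is no step of this kind to lean on; the three values together only show a narrow band.

The step of a number 1.4 percentage points higher from compound 1 to compound 4 (within the scatter) is expected to be none beyond the scatter. For compound 4 the estimate in this assay is 25%, with a range from 12% to 38%.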

Compound 4, a percentage reported as activity, at one dose (the size of the read-out at that dose, not a potency): 28.4%
Beside the measured number, compound 4's estimate is 3.4 percentage points below it; the range from low to high includes it.
By their numbers in this assay, from the lowest: compounds 1, 4, 3 and 2 (each within the scatter of the next).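

In this assay, among these compounds, a number 4.8 percentage points higher from compound 1 to compound 4 (within the scatter) is the first one-place step, and it gives no sign of a difference between 2-carboxypyrrolidin-1-yl and (1-carboxyethyl)amino on this carbonyl carbon at the one dose given. The five-membered ring can therefore be replaced by this open-chain group, which has one more hydrogen-bond donor, without the read-out leaving the scatter. Nothing available bears on why the read-out holds level.

As far as these compounds go, it remains open whether this position responds to any change at all, or whether the tolerance seen here is limited to this one replacement. A primary amide or an amine in place of the carboxylic acid, or a longer chain in place of the methyl of (1-carboxyethyl)amino, would test this further.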